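Compound 3 to compound 4: a hydroxy group enters

The source may hold more compounds than are shown below. What is called first, only, known or untested is meant among the compounds shown, and "the series" means these compounds.

In a functional assay (brain) for inhibition, with Rattus norvegicus as the target (on this read-out lower numbers stand for stronger inhibition and higher numbers for weaker inhibition), compound 1 `Cc1c(C)c2c(c(C)c1O)C(CN1CCN(C)CC1)C(C)(C)O2` gives 450 nM; 400 nM; 400 nM (3 entries), and compound 2 `Cc1c(C)c2c(c(C)c1O)C(CN(C)C)C(C)(C)O2` gives 700 nM. Compound 3 `Cc1c(C)c2c(c(C)c1O)C(C[N+](C)(C)C)C(C)(C)O2`, at 3600 nM, holds the highest number of the three. Compound 4 `Cc1c(C)c2c(c(C)c1O)C(CO)C(C)(C)O2` differs from it by one oxygen atom in place of a group of 4 heavy atoms (3 carbon, 1 nitrogen; no ring), on a saturated chain carbon bound to a saturated ring carbon, so a group with net charge +1 leaves and a hydroxy group with no net charge enters. Within the data shown here, only one measured step bears on this place: a 5.1-fold higher number from compound 2 to compound 3 (0.71 log units; beyond the scatter). Among the measured compounds shown here, that step brought in the group that now leaves, so a modest move to a lower number is expected, although no hydroxy group has yet been measured here. The expected size is a 4.0-fold lower number from compound 3 to compound 4 (0.60 log units; beyond the scatter). For compound 4 the estimate is 900 nM, with an expected range of 300 nM to 3000 nM.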

Compound 4, half-maximal inhibitory concentration: 2600 nM
Estimate against measurement, compound 4: 2.9-fold (0.46 log units) below, and the stated range covers the measured number.
By their numbers in this assay, from the lowest: compound 2; then compounds 4 and 3 (each within the scatter of the next).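

In this assay, putting a hydroxy group with no net charge in place of the group with net charge +1 gives a 1.4-fold lower number from compound 3 to compound 4 (0.14 log units; within the scatter), so these two groups are not told apart at this place. Hydroxy in place of dimethylamino, by contrast, gives a 3.7-fold higher number from compound 2 to compound 4 (0.57 log units; beyond the scatter), so among these compounds the lower number on this chain carbon goes with dimethylamino alone. Nothing measured here gives a cause for either result.

As far as these compounds go, it remains open whether a primary amine, a methoxy group or a carboxylic acid on this chain carbon would side with compound 2 or with compounds 3 and 4.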